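A Ring Exchange on the Chain of Compound 1

The source may hold more compounds than are shown below. What is called first, only, known or untested is meant among the compounds shown, and "the series" means these compounds.

Measured in an ADME assay on microsomes from liver (Rattus norvegicus) for metabolic stability; a lower number here means that the compound disappears faster, a higher number that the compound lasts longer:
- compound 1 `CC(C)C(/C=C1\NC(=O)NC1=O)c1ccc(-c2ccc3cccc(F)c3c2)[nH]c1=O`: 1.46 h
- compound 2 `Cc1cc(C(/C=C2\OC(=O)NC2=O)C(C)C)c(=O)[nH]c1-c1ccc2cccc(F)c2c1`: > 3 h (a limit of the assay, not a number)
- compound 3 `O=C1NC(=O)/C(=C/C(c2ccc(-c3ccc4cccc(F)c4c3)[nH]c2=O)C2CCCCC2)O1`: 2.39 h

Among the measured compounds shown here, compound 1 gives 1.46 h and compound 3 gives 2.39 h, so compound 1 stands within the scatter of the only other compound with a number. For compound 2, the reading of > 3 h is a limit.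

Compound 4 `CC(C)C(/C=C1\SC(=O)NC1=O)c1ccc(-c2ccc3cccc(F)c3c2)[nH]c1=O` has not yet been measured in this assay. Its difference from compound 1 is a group of 8 heavy atoms (4 carbon, 1 nitrogen, 2 oxygen, 1 sulfur; one five-membered non-aromatic ring with 2 hetero atoms) in place of a group of 8 heavy atoms (4 carbon, 2 nitrogen, 2 oxygen; one five-membered non-aromatic ring with 2 hetero atoms), on a saturated chain carbon bound to an aromatic carbon and a saturated chain carbon. The rest of the structure stays the same. For the measured compounds named here, no two measured compounds differ in one place alone, so the data offer no direct size for such a step. Compound 1 at 1.46 h is therefore the starting point, and no change beyond the scatter is expected in either direction. The estimated step of a 1.1-fold higher number from compound 1 to compound 4 (0.04 log units; within the scatter) is expected to stay within the scatter. For compound 4, the estimated half-life is 1.6 h, with an expected range from 0.8 h to 3 h.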

Compound 4, half-life: 2.62 h
For compound 4 the middle estimate is 1.6-fold (0.21 log units) below the measured one, and the stated range covers the measured number.
By their numbers in this assay, from the lowest: compounds 1, 3 and 4 (each within the scatter of the next). At a limit, above all of these: compound 2.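

In this assay, the set now holds its first comparison of compounds that differ in one place, and it reads a 1.8-fold higher number from compound 1 to compound 4 (0.25 log units; within the scatter). At this saturated chain carbon, then, one five-membered non-aromatic ring with 2 hetero atoms can take the place of another, with a sulfur in place of a nitrogen and one hydrogen-bond donor fewer, without a change beyond the scatter. Any further exchange on this carbon would meet the top of the reading range of the assay: the limit of > 3 h in this assay, at which 1 of the 4 values shown sits.

Going by these compounds, whether a carboxylic acid or an amine in place of this ring would keep the half-life within the scatter remains open. So does whether the same ring exchange would give a similar step on a core carrying a cyclohexyl group, as in compound 3.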